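Trimming the ring amine: a single methyl removed

The source may hold more compounds than are shown below. What is called first, only, known or untested is meant among the compounds shown, and "the series" means these compounds.

Measured so far:
Compound 1 `CCN(C)c1nc(N[C@H]2CC[C@@H](NC(=O)c3ccc(F)c(F)c3)CC2)ncc1C` gives 46 nM in a functional assay on HEK293 cells for antagonist activity at melanin-concentrating hormone receptor 1 (Homo sapiens), read by FLIPR and calcium flux; on this read-out higher numbers stand for weaker inhibition and lower numbers for stronger inhibition.
Compound 2 `CNc1nc(N[C@H]2CC[C@@H](CNC(=O)c3cc(C(F)(F)F)cc(C(F)(F)F)c3)CC2)ncc1C` gives 200 nM in this assay.

Compound 2 stands at the higher of the two numbers, and its gap to compound 1 lies beyond the scatter of repeated runs, so compound 2 is the weaker inhibitor of the pair. The two differ in several places at once, so nothing can be said about which part of that difference matters.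

Compound 3 `Cc1cnc(N[C@H]2CC[C@@H](CNC(=O)c3cc(C(F)(F)F)cc(C(F)(F)F)c3)CC2)nc1N` is the next step, and it changes only one thing: hydrogen in place of methyl on a nitrogen on an aromatic ring. The amide, the trifluoromethyl-bearing ring and the rest of the core stay as they are. Within the data shown here, no measured pair shows this exact change, so there is no step to lean on. A change this small, hydrogen in place of methyl on a nitrogen on an aromatic ring, is expected to move the number only modestly, with no clear direction. The expected step of a 1.3-fold higher number from compound 2 to compound 3 (0.10 log units; within the scatter) is estimated to stay within the usual scatter. Compound 3 is expected to give 250 nM, within a range from 80 nM to 800 nM.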

Compound 3, half-maximal inhibitory concentration: 600 nM
Compound 3: middle estimate off by 2.4-fold (0.38 log units), on the low side; the measured number falls inside the stated range.
By their numbers in this assay, from the lowest: compound 1; then compound 2; then compound 3.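

Taking the methyl off the nitrogen, so that methylamino becomes amino, gives a 3.0-fold higher number from compound 2 to compound 3 (0.48 log units; beyond the scatter) in this assay, which makes compound 3 the weaker inhibitor of the pair. Among these compounds, this is the first comparison here that differs in one place, and it shows that this nitrogen is not indifferent to what it carries: the loss of a single carbon is enough to move the number past the usual scatter, while the amide and the trifluoromethyl-bearing ring stay the same. The methyl therefore counts for something at this position, although nothing measured here explains how it does so.

The compounds shown give no sign of what happens when this nitrogen carries something larger, such as a propyl chain or a pyrrolidine ring, so it remains unknown whether the number would keep falling as the group grows or would turn upward again. Among the compounds shown here, it also remains open whether removing this methyl would cost as much with a different amide, such as the one in compound 1, since this step has been read with only one amide in place.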